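Trifluoromethyl removal on the urea phenyl of compound 1

The source may hold more compounds than are shown below. What is called first, only, known or untested is meant among the compounds shown, and "the series" means these compounds.

Growth inhibition was measured in a functional assay on SK-MEL-5 cells (Homo sapiens) for inhibition, read by sulforhodamine B assay, with a stated time of 48 h (on this read-out higher numbers stand for weaker inhibition of growth and lower numbers for stronger inhibition of growth), for three compounds of this series.

Compound 1 `COc1cc(-c2nn(-c3cccc(NC(=O)Nc4cc(C(F)(F)F)cc(C(F)(F)F)c4)c3)cc2-c2ccncc2)ccc1Cl`: 694 nM
Compound 2 `COc1cc(-c2nn(-c3cccc(NC(=O)c4cccc(C(F)(F)F)c4)c3)cc2-c2ccncc2)ccc1Cl`: 978 nM
Compound 3 `O=C(Nc1cccc(-n2cc(-c3ccncc3)c(-c3ccc(Cl)c(O)c3)n2)c1)Nc1ccc(Cl)c(Cl)c1`: 570 nM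

In this assay compound 1 lies between compound 3 and compound 2, and the three numbers fall within the scatter of one another, so no ranking among them can be drawn from these values. The amide of compound 2 and the dichlorophenyl urea of compound 3 give numbers of the same size as the bis-trifluoromethyl urea of compound 1.

Compound 4 `COc1cc(-c2nn(-c3cccc(NC(=O)Nc4cccc(C(F)(F)F)c4)c3)cc2-c2ccncc2)ccc1Cl` has not yet been measured. It differs from compound 1 in one place: hydrogen in place of trifluoromethyl on an aromatic carbon. Going by the values given here, no step between measured compounds isolates this change. Given that compound 1 694 nM, compound 2 978 nM and compound 3 570 nM all sit close together despite different substitution on the urea or amide phenyl, the expected step in this assay from compound 1 to compound 4 is small, at most a slight weakening, and likely not beyond the scatter: a 1.3-fold higher number from compound 1 to compound 4 (0.11 log units; within the scatter) is the estimated step. Compound 4 is therefore expected to give about 900 nM in this assay, with a range from 400 nM to 2500 nM.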

Compound 4, concentration for 50% growth inhibition: 720 nM
The estimate for compound 4 lay 1.3-fold (0.10 log units) above the measured number; the measured number falls inside the stated range.
By their numbers in this assay, from the lowest: compounds 3, 1, 4 and 2 (each within the scatter of the next).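

In this assay, hydrogen in place of one trifluoromethyl on the urea phenyl gives no readable shift (a 1.0-fold higher number from compound 1 to compound 4 (0.02 log units; within the scatter)), so this aromatic carbon tolerates loss of the group with the urea held constant. Going by these compounds alone, the urea and amide links, each carrying a single trifluoromethyl, also cannot be separated (a 1.4-fold lower number from compound 2 to compound 4 (0.13 log units; within the scatter)), a comparison that the earlier compounds, differing in more than one place, could not give. Nothing available bears on why these numbers stay so close.

On these data alone, it remains open whether hydrogen in place of the remaining trifluoromethyl would leave the number within the scatter. As far as these compounds go, it also remains open whether an amine or a carboxylic acid on this aromatic carbon would shift the number beyond the scatter.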